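The compounds below may be only part of what the source reports. "The series", "measured", "known", "first", "only" and "open" are said of these compounds alone.

Compound 1 `CCCCN(c1nc2c(C(=O)NC)cccc2o1)[C@H](C)c1ccc(-c2ccccc2-c2nnn[nH]2)cc1` is the weakest of the three measured compounds in a functional assay on CAL1 cells for inhibition of chemerin-like receptor 1 (Homo sapiens), with a stated time of 45 min (on this read-out higher numbers stand for weaker inhibition and lower numbers for stronger inhibition), where compound 1 gives 110 nM. The nearest measured neighbour, compound 2 `Cc1ccc(-c2nc(=O)o[nH]2)c(-c2ccc([C@@H](C)N(CC3CC3)c3nc4c(C(=O)O)cccc4o3)cc2)c1`, gives 3.2 nM in this assay, a far lower number and thus a far stronger inhibitor, while compound 3 `CCCCN(c1nc2c(C(=O)O)cccc2o1)[C@H](C)c1ccc(-c2cc(Cl)ccc2-c2nc(=O)o[nH]2)cc1` gives 1.2 nM, lower still. Both gaps lie well beyond the usual scatter, but compounds 2 and 3 differ from compound 1 in several places at once, so no single structural step can be read from them.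

Compound 4 `CCCCN(c1nc2c(C(=O)NS(C)(=O)=O)cccc2o1)[C@H](C)c1ccc(-c2ccccc2-c2nnn[nH]2)cc1` is a new, unmeasured compound that differs from compound 1 in one place: methylsulfonyl in place of methyl on an amide-type nitrogen. Going by the values given here, no pair of measured compounds isolates this particular change, so its effect has to be estimated rather than read off. The step from compound 1 to compound 4 is expected to go toward stronger inhibition, a moderate step of about a 3.7-fold lower number from compound 1 to compound 4 (0.56 log units; beyond the scatter), larger than the scatter but smaller than the gaps from compound 1 to compounds 2 and 3. Compound 4 is therefore estimated to give about 30 nM in this assay, with a plausible range from 8 nM to 120 nM, pending the actual measurement.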

Compound 4, half-maximal inhibitory concentration: 14 nM
Estimate against measurement, compound 4: 2.1-fold (0.33 log units) above; measured number inside the range.
By their numbers in this assay, from the lowest: compound 3; then compound 2; then compound 4; then compound 1.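

Going by these compounds alone, the replacement of methyl by methylsulfonyl on an amide-type nitrogen gives the first step in this set that can be read at a single place: in this assay there is a 7.9-fold lower number from compound 1 to compound 4 (0.90 log units; beyond the scatter) and this modest gain in inhibition lies beyond the usual scatter. The earlier compounds shown here could not show this, as each differs from compound 1 in several places at once; this pair shows that, with the rest of compound 1 held fixed, the group on this nitrogen affects the result and a larger group is tolerated here. Nothing measured here explains why the number falls, so the step records an effect and not its cause.

The compounds shown leave open whether ethylsulfonyl or phenylsulfonyl on this nitrogen would lower the number further, and whether a primary amide, with hydrogen in place of methyl, would stand nearer compound 1 or compound 4. As far as these compounds go, compounds 2 and 3 carry a carboxylic acid instead of this amide but also differ elsewhere, so how that group ranks against methylsulfonyl on an otherwise unchanged compound 1 remains unknown.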